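The source may hold more compounds than are shown below. What is called first, only, known or untested is meant among the compounds shown, and "the series" means these compounds.

Two compounds with the same core were tested for their effect on cell viability. Compound 1 `COc1ccc(C(=O)CCc2cccc(OC)c2OC)c(O)c1` and compound 2 `COc1ccc(CCCc2ccc(OC)c(OC)c2OC)c(O)c1` both went into an ADME assay on RAW264.7 cells (Mus musculus) for cytotoxicity, read by MTT assay, with a stated time of 24 h, tested at 10 ug/mL; a higher number here means a weaker effect of the compound at the concentration tested, a lower number a stronger effect. In this assay compound 1 gives 92.8%, the highest of the two numbers. In this assay compound 2 gives 36.7%, a number well below that of compound 1 and beyond the scatter, though the two structures differ in more than one place, so no single change can be read from the pair. Compound 3 `COc1ccc(C(=O)CCc2ccc(OC)c(OC)c2OC)c(O)c1` has not been measured yet. It differs from compound 1 by methoxy in place of hydrogen on an aromatic carbon, on an aromatic carbon ortho to a methoxy group, meta to a methoxy group and para to a large group. Because compound 2, which also carries three methoxy groups, gives 36.7%, a step toward a stronger effect is expected, of moderate size. Compound 3 is estimated at 72%, between 40% and 97%, which means an expected step of a number 20.8 percentage points lower from compound 1 to compound 3 (beyond the scatter).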

Compound 3, a percentage reported as activity, at one concentration (the size of the read-out at that concentration, not a potency): 94%
Beside the measured number, compound 3's estimate is 22 percentage points below it; the range from low to high includes it.
By their numbers in this assay, from the lowest: compound 2; then compounds 1 and 3 (each within the scatter of the next).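

In this assay, the step from adding methoxy in place of hydrogen on an aromatic carbon, ortho to a methoxy group, meta to a methoxy group and para to a large group, is a number 1.2 percentage points higher from compound 1 to compound 3 (within the scatter), so the two compounds cannot be told apart at this position. With the same three methoxy groups on that ring as compound 3, compound 2 gives 36.7%, so this added methoxy alone does not account for that number. Nothing measured here explains why the change leaves the read-out within the scatter.

From the compounds shown here alone, it remains open whether the carbonyl of compound 3 is what separates it from compound 2. Going by these compounds, it is also open whether a different group at this position, such as ethoxy, an amine or a carboxylic acid, would give a number like that of compound 3.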